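This account rests on a few compounds, and the source may have more. Where it says the series, first, only, none or still open, it means among the compounds named here.

Series measured in a functional assay on A549 cells (Homo sapiens) for cytotoxicity, read by MTT assay, with a stated time of 24 h; on this read-out higher numbers stand for weaker inhibition and lower numbers for stronger inhibition:
- compound 1 `Nc1cccn2cc(Cc3ccccc3)c(=O)nc12`: 98000 nM
- compound 2 `O=c1nc2ccc(Br)cn2cc1Cc1ccccc1`: > 1000000 nM (a limit of the assay, not a number)
- compound 3 `O=c1nc2ccccn2cc1Cc1ccccc1`: 104000 nM

In this assay compound 3 gives 104000 nM, within the scatter of compound 1, as the step of a 1.1-fold higher number from compound 1 to compound 3 (0.03 log units; within the scatter) shows. The step of an at least 9.6-fold lower number from compound 2 to compound 3 (0.98 log units; beyond the scatter) is the only one beyond the scatter, and its size is only a bound, as it rests on (the limit of > 1000000 nM in this assay, at which 1 of the 3 values shown sits).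

Compound 4 `O=c1nc2ccccn2cc1Cc1cccc(Oc2ccccc2)c1` differs from compound 3 by phenoxy in place of hydrogen on an aromatic carbon of a six-membered aromatic ring of carbon only, meta to a large group. Neither measured step touches that ring, since both lie on the shared core, so they bear on it only indirectly. Compound 1 shows a substituent change with no effect beyond the scatter, while compound 2 shows one that goes against compound 3. No direction is therefore expected with confidence, and the central expectation is no shift beyond the scatter, with a wide margin. The expected change is a 1.2-fold lower number from compound 3 to compound 4 (0.06 log units; within the scatter). The estimated value for compound 4 is 90000 nM, with an expected range from 25000 nM to 400000 nM.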

Compound 4, half-maximal inhibitory concentration: > 1000000 nM
Compound 4: only a limit was reported; the forecaster's own chance of this, stated with the estimate: 15%; at least 11-fold (1.04 log units) between middle value and limit.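

Among these compounds, the earlier compounds changed only the shared core, so the step of an at least 9.6-fold higher number from compound 3 to compound 4 (0.98 log units; beyond the scatter) is the first reading on the six-membered aromatic ring of carbon only, and it shows that in this assay phenoxy in place of hydrogen at this place, meta to a large group, weakens the read-out beyond the scatter. Compound 4 gives > 1000000 nM, which is a limit of the assay and not a number. The size of the step is thus only a bound, and a change on the core in compound 2 and a change on this ring in compound 4 now end at the same limit: the limit of > 1000000 nM in this assay, at which 2 of the 4 values shown sit.

The compounds shown leave open whether this weakening belongs to phenoxy itself or to any substituent at this place. A methoxy or a fluoro group on the same carbon would help to separate these two readings.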